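The source may report more compounds than this note shows. Statements on the series, on what has been measured and on what is new or still open speak of the compounds shown alone.

Measured compounds:
- compound 1, `C[C@]1(O)C[C@](c2cccc(OC(F)(F)F)c2)([C@H](O)c2ccccn2)C1`: 1310 nM
- compound 2, `O[C@H](c1ccccn1)[C@]1(c2cccc(OC(F)(F)F)c2)C[C@H](O)C1`: 40 nM
- compound 3, `C[C@]1(O)C[C@](c2ccnc(C(F)(F)F)c2)([C@H](O)c2ccccn2)C1`: 500 nM

All three were tested in an assay on HEK293 cells for antagonist activity at transient receptor potential cation channel subfamily V member 3 (Homo sapiens), read by FLIPR and calcium flux; on this read-out higher numbers stand for weaker inhibition and lower numbers for stronger inhibition. Compound 1 and compound 2 share a core and differ in one place: hydrogen in place of methyl on a saturated ring carbon. That single change gave a 33-fold lower number from compound 1 to compound 2 (1.52 log units; beyond the scatter), so removing the methyl from the four-membered ring made the inhibitor much stronger.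

Compound 3 carries a different core; how its core differs from that of compound 1 is not broken down here. In this assay compound 3 gives 500 nM, a lower number than compound 1 and a higher one than compound 2.

Compound 4, `O[C@H](c1ccccn1)[C@]1(c2ccnc(C(F)(F)F)c2)C[C@H](O)C1`, has not yet been measured. It stands to compound 3 as compound 2 stands to compound 1, with the same change: hydrogen in place of methyl on a saturated ring carbon. The place of the change is described in the same words for both pairs, so this is the same change made on a second core.

Among the compounds with values here, only one measured example of this change exists, and it is large. If compound 4 follows compound 3 in the way that compound 2 followed compound 1, with a 33-fold lower number from compound 1 to compound 2 (1.52 log units; beyond the scatter) as the guide, a step of roughly a 25-fold lower number from compound 3 to compound 4 (1.40 log units; beyond the scatter) is expected, perhaps somewhat smaller since a single example may overstate the effect. On that basis, compound 4 is expected to give about 20 nM in this assay, most likely between 6 nM and 70 nM.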

Compound 4, antagonist equilibrium constant: 60 nM
Compound 4: the middle estimate sits 3.0-fold (0.48 log units) below what was measured; the measured number falls inside the stated range.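

Taking the methyl off the four-membered ring in this assay gave an 8.3-fold lower number from compound 3 to compound 4 (0.92 log units; beyond the scatter), so on both cores shown the change moves the same way, towards stronger inhibition. The direction carried over from one core to the other, but the size did not, and the gap between the two steps is larger than chance scatter would explain: the same change on two cores in this assay, a 33-fold lower number (1.52 log units; beyond the scatter) from compound 1 to compound 2 and an 8.3-fold lower number (0.92 log units; beyond the scatter) from compound 3 to compound 4, 3.9-fold (0.59 log units) apart, beyond the scatter of two such steps. Two cores are too few to support a general rule, so these results suggest only that the direction may hold on a further core, and they neither give a reliable size for the step there nor explain why it is smaller on the core of compound 3.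

The compounds shown carry only methyl or hydrogen at this saturated ring carbon, so it remains open what an ethyl group, a longer chain or an amine would do in the same place. Going by these compounds, it also remains open whether the step would keep its direction on a core carrying a nitrile in place of the trifluoromethoxy or trifluoromethyl group.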